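Antiproliferative series on a dimethoxy quinolone core

This account rests on a few compounds, and the source may have more. Where it says the series, first, only, none or still open, it means among the compounds named here.

Measured so far:
compound 1 `COC(=O)c1cc(=O)c2c(OC)cc(OC)cc2n1S(=O)(=O)c1ccc(C)cc1` — 6000 nM
compound 2 `COc1cc(OC)c2c(=O)cc(C(=O)Nc3ccc(Oc4ccc([N+](=O)[O-])cc4)cc3)[nH]c2c1` — 20500 nM

In a functional assay on KOPN-8 cells (Homo sapiens) for antiproliferative activity, with a stated time of 72 h (a higher number here means that more compound is needed for the effect, a lower number that less compound is needed), compound 1 gives 6000 nM and compound 2 gives 20500 nM. Compound 2 therefore stands at the higher of the two numbers, and its gap to compound 1 lies beyond the scatter of this assay. Going by the values given here, the two compounds differ in more than one place, so no single step between them is available.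

Compound 3 `COc1cc(OC)c2c(=O)cc(C(=O)Nc3ccc(-n4cccc4)cc3)[nH]c2c1` follows from compound 2 by one change: 1H-pyrrol-1-yl in place of 4-nitrophenoxy on an aromatic carbon. Nothing measured in this assay isolates this exchange, so the expected size of the step rests on the change alone and on the value of compound 2. A step no larger than the usual scatter is expected, with no firm direction; compound 3 is estimated at 15000 nM, within a range of 4000 nM to 60000 nM. The step from compound 2 to compound 3 that this estimate means is a 1.4-fold lower number from compound 2 to compound 3 (0.14 log units; within the scatter).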

Compound 3, half-maximal effective concentration: > 77000 nM
Compound 3: no number, only a limit; the forecaster's own chance of this, stated with the estimate: 25%; middle value at least 5.1-fold (0.71 log units) away from the limit.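

This position, on the six-membered aromatic ring of carbon only and para to a large group, is sensitive to its substituent in this assay: the exchange of 4-nitrophenoxy for 1H-pyrrol-1-yl gives an at least 3.7-fold higher number from compound 2 to compound 3 (0.57 log units; beyond the scatter). Going by these compounds alone, this is the first single-place step, and it points towards more compound being needed. For compound 3 the entry > 77000 nM is a limit and not a number: the limit of > 77000 nM in this assay, at which 1 of the 3 values shown sits.

As far as these compounds go, it remains open whether the step follows the loss of the ether oxygen, the nitro group or the six-membered ring, which a plain phenoxy group or an amine in place of the nitro group could help to separate. From the compounds shown here alone, the full size of the step also stays open while compound 3 has only a limit.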